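A few compounds are considered here, and "the series" means these few. Any claim that something is new, unique, unknown or untested is made for them only; others in the source may bear on it.

Measured so far:
- Compound 1 `OC[C@H]1O[C@@H](n2cnc3c(NCc4cccc(F)c4)ncnc32)[C@H](O)[C@@H]1O`: 84000 nM
- Compound 2 `Cc1cccc(CNc2ncnc3c2ncn3[C@@H]2O[C@H](CO)[C@@H](O)[C@H]2O)c1`: > 166000 nM (a limit of the assay, not a number)
- Compound 3 `COc1cc(CNc2ncnc3c2ncn3[C@@H]2O[C@H](CO)[C@@H](O)[C@H]2O)cc(OC)c1`: "not determined" (no result reported)

In an ADME assay on NIH3T3 cells (Mus musculus) for cytotoxicity, with a stated time of 72 h (on this read-out lower numbers stand for stronger inhibition and higher numbers for weaker inhibition), compound 3 has no number: "not determined" (no result reported). No size or direction can therefore be given for the step to compound 4 `OC[C@H]1O[C@@H](n2cnc3c(NCc4ccc(F)cc4F)ncnc32)[C@H](O)[C@@H]1O`. That step is 2,4-difluorophenyl in place of 3,5-dimethoxyphenyl on a saturated chain carbon bound to a nitrogen on an aromatic ring.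

Among the compounds with values here, the only measured step, an at least 1.9-fold higher number from compound 1 to compound 2 (0.29 log units; that floor lies within the scatter), is methyl in place of fluoro on an aromatic carbon. It is a different change, so it bears only indirectly. Compound 4 shares fluoro on an aromatic carbon with compound 1, and compound 1 gives 84000 nM. For compound 4, a value near 90000 nM is expected, with an estimated range from 35000 nM to 200000 nM.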

Compound 4, half-maximal inhibitory concentration: > 166000 nM
Compound 4: only a limit was reported (the forecaster's own chance of this, stated with the estimate: 35%); at least 1.8-fold (0.26 log units) between middle value and limit.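

In this assay, 2,4-difluorophenyl in place of 3-fluorophenyl at this position gives an at least 1.9-fold higher number from compound 1 to compound 4 (0.29 log units; that floor lies within the scatter). As far as these compounds go, the value of compound 4 is a limit of the assay and not a number, so the true size of that step is unknown. It does show that a fluoro-bearing ring, not only the 3-methylphenyl of compound 2, can end at the same limit: the limit of > 166000 nM in this assay, at which 2 of the 4 values shown sit.

Neither compound 2 nor compound 4 has a number, so the step between them cannot be read. From the compounds shown here alone, how an amine or a carboxylic acid on this ring would behave remains open.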